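The source may hold more compounds than are shown below. What is called first, only, known or untested is meant among the compounds shown, and "the series" means these compounds.

Compound 1 `Cc1c(C(=O)N/N=C\c2ccccc2F)oc2cccc(O)c12` sits at the limit of a functional assay on PC-3 cells (Homo sapiens) for inhibition; on this read-out lower numbers stand for stronger inhibition and higher numbers for weaker inhibition: compound 1 gives >= 40000 nM, a limit rather than a number (the limit of >= 40000 nM in this assay, at which 1 of the 2 values shown sits). Among the compounds with values here, compound 2 `Cc1c(C(=O)N/N=C\c2cccc(O)c2)oc2cccc(O)c12` gives 17600 nM in this assay, the only number in the set so far. The step between them is an at least 2.2-fold lower number from compound 1 to compound 2 (0.35 log units; beyond the scatter), for 3-hydroxyphenyl in place of 2-fluorophenyl on the carbon with a double bond to nitrogen.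

Compound 3 `Cc1c(C(=O)N/N=C\c2ccccn2)oc2cccc(O)c12` changes the same position: pyridin-2-yl in place of 3-hydroxyphenyl on a carbon with a double bond to nitrogen. Within the data shown here, the only measured step concerns a different pair of groups at that carbon, so it bears on compound 3 only as an indication of how much the group there can shift the number. With the donor of the 3-hydroxyphenyl gone, the number is expected to drift back toward weaker inhibition; the expected step is a 1.7-fold higher number from compound 2 to compound 3 (0.23 log units; within the scatter). Compound 3 is estimated at 30000 nM, within 12000 nM to 80000 nM.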

Compound 3, half-maximal inhibitory concentration: >= 40000 nM
Compound 3 was reported as a limit; the forecaster's own chance of this, stated with the estimate: 40%; middle value at least 1.3-fold (0.12 log units) away from the limit.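

Replacing 3-hydroxyphenyl with pyridin-2-yl on the carbon with a double bond to nitrogen gives a clear loss in this assay (an at least 2.2-fold higher number from compound 2 to compound 3 (0.35 log units; beyond the scatter)), so a six-membered aromatic ring at this carbon does not by itself keep a measurable number. The result for compound 3 is a limit, not a number, and it joins compound 1 there: (the limit of >= 40000 nM in this assay, at which 2 of the 3 values shown sit). Of the three groups at this carbon, only 3-hydroxyphenyl gives a number, and the step between compound 1 and compound 3 cannot be read.

Going by these compounds, whether the hydroxyl of the 3-hydroxyphenyl group itself matters remains open; 3-methoxyphenyl or 3-aminophenyl at this carbon would test that. Also open, on these data alone, is whether a carboxylic acid on that ring would move the number in either direction.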